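Heteroaryl swap on the sulfonamide nitrogen

A few compounds are considered here, and "the series" means these few. Any claim that something is new, unique, unknown or untested is made for them only; others in the source may bear on it.

Compound 2 `C=C1CC[C@@H]2[C@](C)(COC(C)=O)[C@H](OC(C)=O)CC[C@@]2(C)[C@H]1CC(Nc1ccc(S(=O)(=O)Nc2nccs2)cc1)C1=CCOC1=O` carries a 1,3-thiazol-2-yl group on the sulfonamide nitrogen. In a functional assay on M14 cells (Homo sapiens) for inhibition, read by sulforhodamine B assay, with a stated time of 48 h (on this read-out higher numbers stand for lower toxicity in this test and lower numbers for higher toxicity in this test), compound 2 gives 42200 nM. Within the data shown here, of the two numbers measured so far this is the lowest, and the nearest is compound 1 `C=C1CC[C@@H]2[C@](C)(COC(C)=O)[C@H](OC(C)=O)CC[C@@]2(C)[C@H]1CC(Nc1ccc(S(=O)(=O)Nc2nccc(C)n2)cc1)C1=CCOC1=O`, which in this assay gives 72600 nM, the two standing within the scatter of each other. Among the measured compounds shown here, the single measured step is a 1.7-fold lower number from compound 1 to compound 2 (0.24 log units; within the scatter), and it does not leave the scatter.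

Compound 3 `C=C1CC[C@@H]2[C@](C)(COC(C)=O)[C@H](OC(C)=O)CC[C@@]2(C)[C@H]1CC(Nc1ccc(S(=O)(=O)Nc2ncccn2)cc1)C1=CCOC1=O` differs from compound 2 by pyrimidin-2-yl in place of 1,3-thiazol-2-yl on a sulfonamide nitrogen. This largely reverses the measured step, except that compound 3 carries pyrimidin-2-yl where compound 1 carries 4-methylpyrimidin-2-yl. For the measured compounds named here, the only bearing evidence is the step from compound 1 to compound 2, which stayed within the scatter, so no step beyond the scatter is expected in this assay in either direction. The estimated step is a 1.3-fold higher number from compound 2 to compound 3 (0.12 log units; within the scatter). Compound 3 is accordingly expected to give 55000 nM in this assay, with a range from 25000 nM to 120000 nM.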

Compound 3, concentration lethal to 50% of the cells: 15900 nM
Compound 3: middle estimate off by 3.5-fold (0.54 log units), on the high side, outside the stated range (below it).
By their numbers in this assay, from the lowest: compound 3; then compounds 2 and 1 (each within the scatter of the next).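

The sulfonamide nitrogen is not indifferent to its heteroaryl group in this assay: pyrimidin-2-yl in place of 1,3-thiazol-2-yl gives a 2.7-fold lower number from compound 2 to compound 3 (0.42 log units; beyond the scatter) and so leaves the scatter, which the earlier change from 4-methylpyrimidin-2-yl to 1,3-thiazol-2-yl did not do. The loss of one methyl matters as well, since hydrogen in place of methyl on an aromatic carbon gives a 4.6-fold lower number from compound 1 to compound 3 (0.66 log units; beyond the scatter) even though the rest of the molecule is unchanged. Among these compounds, compound 3 thus has the lowest number of the series so far, with steps beyond the scatter to both other compounds, and the result depends on the exact heteroaryl group rather than on the ring size alone, as the two six-membered rings of compound 1 and compound 3 differ while compound 1 and the five-membered compound 2 stand within the scatter of each other; no measurement at hand accounts for either step.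

Open, as far as these compounds go, is whether a methoxy group or a chlorine in place of that methyl would also raise the number above that of compound 3. Also open, from the compounds shown here alone, is how a 1,3-oxazol-2-yl or a plain phenyl group on the sulfonamide nitrogen would compare with pyrimidin-2-yl.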